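Methoxy removal on the pyrazole-side ring in the chalcone series

This account rests on a few compounds, and the source may have more. Where it says the series, first, only, none or still open, it means among the compounds named here.

Compound 1 `COc1ccc(-c2cc(/C=C/C(=O)c3ccc(N)cc3)[nH]n2)cc1` and compound 2 `COc1ccc(-c2cc(/C=C/C(=O)c3ccc(N)cc3)[nH]n2)cc1OC` share a core; the difference is hydrogen in place of methoxy on an aromatic carbon. In a functional assay on SNB-19 cells (Homo sapiens) for inhibition, read by sulforhodamine B assay, with a stated time of 48 h (on this read-out higher numbers stand for weaker inhibition of growth and lower numbers for stronger inhibition of growth), compound 2 gives 18000 nM, and compound 1 gives 11600 nM, a step of a 1.6-fold lower number from compound 2 to compound 1 (0.19 log units; within the scatter). Compound 3 `COc1cc(C(=O)/C=C/c2cc(-c3cc(OC)c(OC)c(OC)c3)n[nH]2)cc(OC)c1OC` carries a different core, and how its core differs from that of compound 2 is not broken down here. In this assay compound 3 gives 3690 nM, the lowest of the three numbers, and its gaps to compound 1 and compound 2 are beyond the scatter.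

Compound 4 `COc1ccc(-c2cc(/C=C/C(=O)c3cc(OC)c(OC)c(OC)c3)[nH]n2)cc1OC` is not yet measured. Against compound 3 the change is hydrogen in place of methoxy on an aromatic carbon. This is the same kind of change as from compound 2 to compound 1, but not the same: in compound 3 the place is also meta to a methoxy group, which the place in compound 2 is not. Within the data shown here, the only measured precedent, a 1.6-fold lower number from compound 2 to compound 1 (0.19 log units; within the scatter), stays within the scatter. In this assay the step from compound 3 to compound 4 is therefore expected to be small, a 1.2-fold lower number from compound 3 to compound 4 (0.06 log units; within the scatter). The anchor is compound 3 with 3690 nM. For compound 4 the estimate is 3200 nM, with a range from 1500 nM to 7000 nM.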

Compound 4, concentration for total growth inhibition: 5320 nM
Compound 4: middle estimate off by 1.7-fold (0.22 log units), on the low side; the range from low to high includes it.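

In this assay, hydrogen in place of methoxy on an aromatic carbon gives a 1.4-fold higher number from compound 3 to compound 4 (0.16 log units; within the scatter), so on this core the change stays inside the usual scatter, as it did on the core of compound 1. The two steps carry opposite signs, but this does not count as a reversal, and they cannot be told apart: the same change on two cores in this assay, a 1.6-fold lower number (0.19 log units; within the scatter) from compound 2 to compound 1 and a 1.4-fold higher number (0.16 log units; within the scatter) from compound 3 to compound 4, 2.2-fold (0.35 log units) apart, within the scatter of two such steps

This shows that on these two cores the change produces no step beyond the scatter; it does not show that the change would stay this small on any other core, and two steps are a thin basis for a rule, especially as the place in compound 3 is also meta to a methoxy group.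

Open, as far as these compounds go, is whether a different group at this place, such as a hydroxyl, a fluorine or a carboxylic acid, would give a step beyond the scatter. Also open, from the compounds shown here alone, is whether taking away several methoxy groups together on one core would do so where a single removal does not.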